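A few compounds are considered here, and "the series" means these few. Any claim that something is new, unique, unknown or untested is made for them only; others in the source may bear on it.

Working notes on the series in a functional assay on HL-60 cells (Homo sapiens) for inhibition, read by MTT assay, with a stated time of 72 h; a higher number here means a weaker inhibitor, a lower number a stronger inhibitor:
- compound 1 `Cc1nc(-c2ccccc2)c(C(=O)N2CCN(c3cccc(Cl)c3)CC2)o1`: 39.2 nM
- compound 2 `COc1ccc(-c2nc(C)oc2C(=O)N2CCN(c3cccc(Cl)c3)CC2)cc1OC`: "not active" (no number reported)
- compound 3 `CC(=O)Nc1cccc(-c2nc(C)oc2C(=O)N2CCN(c3cccc(Cl)c3)CC2)c1`: 208 nM

Compound 1 has the lower of the two numbers available, and compound 2 has no number to compare. The next compound is compound 4 `Cc1nc(-c2ccccc2)c(C(=O)N2CCN(c3cccc(C)c3C)CC2)o1`, with 2,3-dimethylphenyl in place of 3-chlorophenyl on an amine nitrogen in a ring. Among the measured compounds shown here, all three measured compounds carry the 3-chlorophenyl group, so no measured step tests this change directly. For the measured compounds named here, the only measured step is a 5.3-fold higher number from compound 1 to compound 3 (0.72 log units; beyond the scatter). It is modest and comes from acetamido in place of hydrogen on an aromatic carbon, a change elsewhere in the molecule. It therefore serves only as a rough guide to size. With compound 1 at the low end of the numbers, a modest rise in this assay is expected, though a result within the scatter would be no surprise. The expected step is a 2.0-fold higher number from compound 1 to compound 4 (0.31 log units; beyond the scatter). For compound 4 the estimated value is 80 nM, with an expected range from 20 nM to 350 nM.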

Compound 4, half-maximal inhibitory concentration: 35 nM
Beside the measured number, compound 4's estimate is 2.3-fold (0.36 log units) above it; low and high end bracket the measured number.
By their numbers in this assay, from the lowest: compounds 4 and 1 (each within the scatter of the next); then compound 3.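

In this assay, among the compounds shown here, the first measured change to the aromatic group on the ring amine nitrogen gives a 1.1-fold lower number from compound 1 to compound 4 (0.05 log units; within the scatter), so 3-chlorophenyl and 2,3-dimethylphenyl cannot be told apart at this position. The earlier step covered only the acetamido change elsewhere in the molecule, whereas this result shows that a group without chlorine can stand here with the number remaining within the scatter of compound 1. No measurement shown bears on the reason for this result.

The compounds shown leave open whether a single methyl, a methoxy group, a trifluoromethyl group or an amine on this phenyl ring would give a similar number. On these data alone, it also remains open whether 2,3-dimethylphenyl would behave the same way alongside the acetamido group of compound 3.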